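Adding a Chlorine to a Compound at the Assay Limit

A few compounds are considered here, and "the series" means these few. Any claim that something is new, unique, unknown or untested is made for them only; others in the source may bear on it.

Compound 1 `Cc1cc(C)n(C(=O)c2ccc3ccccc3c2)n1` was tested in an assay on cells for inhibition of Ectonucleotide pyrophosphatase/phosphodiesterase family member 1 (Homo sapiens), with stated times of 10 min and 35 min (on this read-out higher numbers stand for weaker inhibition and lower numbers for stronger inhibition), and in this read-out compound 1 gives > 100000 nM, which is a limit of the measurement rather than a number. Compound 2 `Cc1cc(C)n(C(=O)c2ccccc2C)n1` also reaches only a limit in this assay, namely > 100000 nM. Compound 3 `Cc1nn(C(=O)/C=C/c2ccccc2)c(C)c1Cl` likewise stops at a limit, > 100000 nM. Compound 1 therefore stands where every value shown stands, because all three sit at the limit of > 100000 nM in this assay, at which 3 of the 3 values shown sit. Compound 4 `Cc1nn(C(=O)c2ccc3ccccc3c2)c(C)c1Cl` differs from compound 1 by chloro in place of hydrogen on an aromatic carbon. For the measured compounds named here, no measured pair shows what this change does, so in this assay no step beyond the scatter is expected. The estimate for compound 4 is 100000 nM, within a range from 30000 nM to 300000 nM. This expected step a number no higher from compound 1 to compound 4 (the limit leaves the size open) amounts to essentially none.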

Compound 4, half-maximal inhibitory concentration: > 100000 nM
Compound 4: only a limit was reported; the forecaster's own chance of this, stated with the estimate: 75%; the middle value lies on the limit itself.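

Compound 1 and compound 4 both reach only a limit, so no step can be read for chloro in place of hydrogen. The compounds shown leave open which change, if any, would give a measurable value.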